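A Smaller Heteroaryl Ring at the Chain Carbon of Compound 3

The source may report more compounds than this note shows. Statements on the series, on what has been measured and on what is new or still open speak of the compounds shown alone.

Measured in an assay on isolated protein for binding affinity to Oxytocin receptor (Homo sapiens); a lower number here means a stronger inhibitor, a higher number a weaker inhibitor:
- compound 1, `CC(C)C[C@@H]1C(=O)N[C@H](C2Cc3ccccc3C2)C(=O)N1[C@@H](C(=O)NC(C)C)c1ccco1`, gives 6.31 nM
- compound 2, `CC(C)C[C@@H]1C(=O)N[C@H](C2Cc3ccccc3C2)C(=O)N1[C@@H](C(=O)NC(C)C)c1ccc(Br)o1`, gives 0.794 nM
- compound 3, `CC(C)C[C@@H]1C(=O)N[C@H](C2Cc3ccccc3C2)C(=O)N1[C@@H](C(=O)NC(C)C)c1ccc(-c2ccccn2)s1`, gives 2.51 nM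

Compound 3 stands second highest of the three numbers in this assay. Its nearest neighbour is compound 1, and that gap is a 2.5-fold lower number from compound 1 to compound 3 (0.40 log units; beyond the scatter). Its furthest neighbour is compound 2, and that gap is a 3.2-fold higher number from compound 2 to compound 3 (0.50 log units; beyond the scatter).

Compound 4, `Cc1nc([C@H](C(=O)NC(C)C)N2C(=O)[C@@H](C3Cc4ccccc4C3)NC(=O)[C@H]2CC(C)C)co1`, has not yet been measured. It differs from compound 3 by 2-methyl-1,3-oxazol-4-yl in place of 5-(pyridin-2-yl)thiophen-2-yl on a saturated chain carbon bound to an amide-type nitrogen in a ring and a carbonyl carbon.

Among the compounds with values here, two measured steps touch the same place on the shared core. The step of a 2.5-fold lower number from compound 1 to compound 3 (0.40 log units; beyond the scatter) shows that the five-membered ring bearing the six-membered ring lowers the number against the bare furan-2-yl of compound 1, and the step of a 3.2-fold higher number from compound 2 to compound 3 (0.50 log units; beyond the scatter) shows that it still falls short of the 5-bromofuran-2-yl of compound 2. The 2-methyl-1,3-oxazol-4-yl of compound 4 is closer in size to the furan-2-yl of compound 1 than to either larger group, so the number is expected to move back toward compound 1: a modest rise, of about a 3.2-fold higher number from compound 3 to compound 4 (0.50 log units; beyond the scatter), is expected. For compound 4 the estimate is 8 nM, with a range from 2.5 nM to 25 nM.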

Compound 4, inhibition constant: 1.26 nM
Beside the measured number, compound 4's estimate is 6.3-fold (0.80 log units) above it; the measured number lies below the stated range.
By their numbers in this assay, from the lowest: compounds 2, 4 and 3 (each within the scatter of the next, the first and the last beyond it); then compound 1.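

In this assay, this change shows that the low number at this position does not depend on the larger two-ring group: a 2.0-fold lower number from compound 3 to compound 4 (0.30 log units; within the scatter), which lies within the scatter, even though 2-methyl-1,3-oxazol-4-yl has fewer heavy atoms than 5-(pyridin-2-yl)thiophen-2-yl. The new group also cannot be separated from 5-bromofuran-2-yl, with a 1.6-fold higher number from compound 2 to compound 4 (0.20 log units; within the scatter), again within the scatter, yet it stands clearly apart from the bare furan-2-yl, with a 5.0-fold lower number from compound 1 to compound 4 (0.70 log units; beyond the scatter), which is beyond the scatter. A single five-membered heteroaryl ring can therefore match the results of compound 2 and compound 3 at this chain carbon, but having such a ring does not guarantee this, as compound 1 goes against that pattern, and no evidence is available to explain these differences.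

The compounds shown leave open what the methyl of 2-methyl-1,3-oxazol-4-yl contributes, as a comparison with the same ring bearing hydrogen in its place would be needed to separate the methyl from the ring. Also open, from the compounds shown here alone, is how an amine or a carboxylic acid on this ring would read in this assay.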